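Meta substituent swap on the benzylamine arm: phenyl for trifluoromethyl

This account rests on a few compounds, and the source may have more. Where it says the series, first, only, none or still open, it means among the compounds named here.

Working notes on the series. Compound 1 `O=C(O)CCc1ccc(NCc2cccc(Br)c2)cc1` carries a bromo group on the benzylic aromatic ring; in a functional assay on 1321-N1 cells for agonist activity at Free fatty acid receptor 1 (Homo sapiens), read by calcium flux (a higher number here means that more compound is needed for the effect, a lower number that less compound is needed), compound 1 gives 174 nM. Compound 2 `O=C(O)CCc1ccc(NCc2cccc(C(F)(F)F)c2)cc1` carries a trifluoromethyl group in the same position, and in this assay compound 2 gives 186 nM. The step of a 1.1-fold higher number from compound 1 to compound 2 (0.03 log units; within the scatter) is the only one available so far. On the two numbers shown, compound 2 stands with the higher value, but the gap to compound 1 is within the scatter, so the two are effectively equal.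

Compound 3 `O=C(O)CCc1ccc(NCc2cccc(-c3ccccc3)c2)cc1` is the next member: phenyl in place of trifluoromethyl on an aromatic carbon, with the new group sitting on an aromatic carbon of a six-membered aromatic ring of carbon only, meta to a large group. For the measured compounds named here, no measured step involves a phenyl group, so nothing bears on this change directly; the single step from compound 1 to compound 2 shows only that the two halogen-type substituents were interchangeable. Going by the values given here, with no precedent for the larger group, the step of a 1.6-fold lower number from compound 2 to compound 3 (0.19 log units; within the scatter) is expected to be modest, and a number near or somewhat below that of compound 2 is the best estimate. For compound 3 in this assay the estimate is 120 nM, with a plausible range from 40 nM to 400 nM.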

Compound 3, half-maximal effective concentration: 53.7 nM
Compound 3: middle estimate off by 2.2-fold (0.35 log units), on the high side; the range from low to high includes it.
By their numbers in this assay, from the lowest: compound 3; then compounds 1 and 2 (each within the scatter of the next).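

Until now this position had shown no response to the substituent, since bromo and trifluoromethyl could not be told apart in this assay. The phenyl group gives the first separation beyond the scatter at this aromatic carbon, with a 3.5-fold lower number from compound 2 to compound 3 (0.54 log units; beyond the scatter) and, against the bromo group, a 3.2-fold lower number from compound 1 to compound 3 (0.51 log units; beyond the scatter), so the position does tolerate a six-membered aromatic ring of carbon only and the number moves down with it. The counts for the trifluoromethyl-to-phenyl change show 6 heavy atoms entering for 4 leaving, a ring entering where none left, and 0 hydrogen-bond donors and 0 hydrogen-bond acceptors on both sides, but no available measurement explains the lower number.

On these data alone, it remains open whether the aromatic character of the ring matters, which a cyclohexyl group in the same place would test, or whether a ring nitrogen, as in a pyridyl group, keeps the number of compound 3. Also open, as far as these compounds go, is whether a phenoxy or benzyl group, which sets the ring further out through one more linking atom, carries the trend further or reverses it.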